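Swapping an Amide Chain for an Aromatic Oxazole Ring

The source may report more compounds than this note shows. Statements on the series, on what has been measured and on what is new or still open speak of the compounds shown alone.

Compound 1 `CC(C)CCn1nc(-c2cccs2)c(O)c(C2=NS(=O)(=O)c3cc(OCC(N)=O)ccc3N2)c1=O`, compound 2 `CCC(Oc1ccc2c(c1)S(=O)(=O)N=C(c1c(O)c(-c3cccs3)nn(CCC(C)C)c1=O)N2)C(N)=O` and compound 3 `CC(C)CCn1nc(-c2cccs2)c(O)c(C2=NS(=O)(=O)c3cc(CCC(N)=O)ccc3N2)c1=O` share one core and differ only in the group on the outer benzene ring. In an in vitro ADME assay on microsomes from liver (Homo sapiens) for metabolic stability, tested at 5 uM (a higher number here means that the compound lasts longer, a lower number that the compound disappears faster), compound 1 gives 0.383 h. Compound 2 gives 0.35 h in this assay, a change of a 1.1-fold lower number from compound 1 to compound 2 (0.04 log units; within the scatter). For compound 3 the assay reports only a limit, > 1 h. The steps of an at least 2.6-fold higher number from compound 1 to compound 3 (0.41 log units; beyond the scatter) and an at least 2.8-fold higher number from compound 2 to compound 3 (0.45 log units; beyond the scatter) both finish at that limit, as the limit of > 1 h in this assay, at which 1 of the 3 values shown sits, records. Compound 4 `CC(C)CCn1nc(-c2cccs2)c(O)c(C2=NS(=O)(=O)c3cc(-c4cnoc4)ccc3N2)c1=O` differs from compound 3 by 1,2-oxazol-4-yl in place of 2-carbamoylethyl on an aromatic carbon. Within the data shown here, no measured step exchanges an amide-bearing chain for an aromatic ring, so the two steps into compound 3 only show that changes at this position can move the number beyond the scatter, in either direction. With compound 3 itself known only as a limit, the step to compound 4 is expected to be an at least 1.2-fold lower number from compound 3 to compound 4 (0.09 log units; that floor lies within the scatter), carrying wide uncertainty. The estimate for compound 4 is 0.8 h, ranging from 0.3 h to 2 h.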

Compound 4, half-life: 0.5 h
Beside the measured number, compound 4's estimate is 1.6-fold (0.20 log units) above it, within the range that was stated.
By their numbers in this assay, from the lowest: compounds 2, 1 and 4 (each within the scatter of the next). At a limit, above all of these: compound 3.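

Among the compounds shown, 1,2-oxazol-4-yl is the only aromatic ring on this aromatic carbon, and in this assay the swap from either oxygen-linked amide chain stays within the scatter: the steps are a 1.3-fold higher number from compound 1 to compound 4 (0.12 log units; within the scatter) and a 1.4-fold higher number from compound 2 to compound 4 (0.15 log units; within the scatter). Against 2-carbamoylethyl the printed step is an at least 2.0-fold lower number from compound 3 to compound 4 (0.30 log units; that floor lies within the scatter), so the ring can be placed here, but this floor alone does not establish a real loss. The full size of that step stays unknown because compound 3 is recorded only as a limit: the limit of > 1 h in this assay, at which 1 of the 4 values shown sits.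

Still open, as far as these compounds go, is how a carboxylic acid, an amine or a longer carbon chain on this aromatic carbon would behave in this assay. A phenyl ring or another five-membered aromatic ring here would show whether the result belongs to 1,2-oxazol-4-yl or to aromatic rings more widely.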